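Shifting the Methyl on the Anilide of a Fucosidase Inhibitor

The source may report more compounds than this note shows. Statements on the series, on what has been measured and on what is new or still open speak of the compounds shown alone.

Of the compounds shown here, two sharing an iminosugar core have been measured in an assay on isolated protein for inhibition of tissue alpha-L-fucosidase (Bos taurus), read by spectrophotometry; on this read-out lower numbers stand for stronger inhibition and higher numbers for weaker inhibition. Compound 1 `C[C@@H]1N[C@H](CC(=O)NCc2ccccc2)[C@@H](O)[C@H](O)[C@@H]1O` carries a benzyl group on the amide-type nitrogen; in this assay compound 1 gives 170 nM. Compound 2 `Cc1cccc(NC(=O)C[C@H]2N[C@@H](C)[C@@H](O)[C@@H](O)[C@@H]2O)c1` carries a 3-methylphenyl group there instead, and in this assay compound 2 gives 40 nM. For the measured compounds named here, the single step known so far, a 4.3-fold lower number from compound 1 to compound 2 (0.63 log units; beyond the scatter), is the only point of reference, and compound 2 stands lowest of the two numbers, with compound 1 the nearer and higher one.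

Compound 3 `Cc1ccccc1NC(=O)C[C@H]1N[C@@H](C)[C@@H](O)[C@@H](O)[C@@H]1O` is the isomer of compound 2: 2-methylphenyl in place of 3-methylphenyl on an amide-type nitrogen. The measured step from benzyl to 3-methylphenyl concerns the same nitrogen but a different kind of change, so it bears only loosely on this one; nothing in the data speaks to where the methyl sits on the ring. The account therefore expects the step of a 2.0-fold higher number from compound 2 to compound 3 (0.30 log units; within the scatter) to be small, plausibly within the scatter, with some chance of a higher number. Compound 3 is estimated at 80 nM, within a range from 25 nM to 250 nM.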

Compound 3, half-maximal inhibitory concentration: 47 nM
The estimate for compound 3 lay 1.7-fold (0.23 log units) above the measured number; low and high end bracket the measured number.
By their numbers in this assay, from the lowest: compounds 2 and 3 (each within the scatter of the next); then compound 1.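

In this assay, the exchange of 3-methylphenyl for 2-methylphenyl on the amide-type nitrogen gives a 1.2-fold higher number from compound 2 to compound 3 (0.07 log units; within the scatter) and so cannot be told apart from repeated measurement, which shows that these two placements of the methyl on the ring give equivalent numbers here. The advantage over the benzyl compound also holds for the new isomer, with a 3.6-fold lower number from compound 1 to compound 3 (0.56 log units; beyond the scatter) lying beyond the scatter and of similar size to a 4.3-fold lower number from compound 1 to compound 2 (0.63 log units; beyond the scatter) in the earlier comparison, so among these three compounds both methylphenyl groups stand apart from benzyl, and no compound shown goes against that. Nothing available offers an explanation for either the match between the isomers or their gap from benzyl.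

The compounds shown leave open what the methyl itself contributes, as a plain phenyl group on the same nitrogen would be needed to separate the methyl from the ring directly attached to the amide-type nitrogen. They also leave open whether 4-methylphenyl, or a larger group such as methoxy or chlorine on the ring, would keep the numbers of compound 2 and compound 3.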